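From Phenyl to 5-Chloro-2-methylphenyl on the Amine Nitrogen

The compounds below may be only part of what the source reports. "The series", "measured", "known", "first", "only" and "open" are said of these compounds alone.

Three compounds were measured in a functional assay on CHO-K1 cells for antagonist activity at transient receptor potential cation channel subfamily V member 1 (Homo sapiens), read by FLIPR; a lower number here means a stronger inhibitor, a higher number a weaker inhibitor:

Compound 1, `CC1CCC(Nc2nc(C(F)(F)F)ccc2CNC(=O)C(C)c2ccc(NS(C)(=O)=O)c(F)c2)CC1`: 27.2 nM
Compound 2, `CC(C(=O)NCc1ccc(C(F)(F)F)nc1NCC1CCN(C(=O)OC(C)(C)C)CC1)c1ccc(NS(C)(=O)=O)c(F)c1`: 19.3 nM
Compound 3, `CC(C(=O)NCc1ccc(C(F)(F)F)nc1Nc1ccccc1)c1ccc(NS(C)(=O)=O)c(F)c1`: 59.6 nM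

Compound 3 gives the highest number of the three. The step of a 2.2-fold higher number from compound 1 to compound 3 (0.34 log units; beyond the scatter) lies beyond the scatter, and the values of compound 3 and compound 2 also show a gap beyond the scatter, so compound 3 is the weakest inhibitor here.

Compound 4, `Cc1ccc(Cl)cc1Nc1nc(C(F)(F)F)ccc1CNC(=O)C(C)c1ccc(NS(C)(=O)=O)c(F)c1`, differs from compound 3 by 5-chloro-2-methylphenyl in place of phenyl on a nitrogen on an aromatic ring. Among the measured compounds shown here, no measured step adds substituents to the phenyl; the only step that touches this position, a 2.2-fold higher number from compound 1 to compound 3 (0.34 log units; beyond the scatter), exchanges the whole group. A modest gain is therefore expected, a 2.4-fold lower number from compound 3 to compound 4 (0.38 log units; beyond the scatter), with wide uncertainty. Compound 4 is estimated at 25 nM, between 8 nM and 80 nM.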

Compound 4, inhibition constant: 14 nM
For compound 4 the middle estimate is 1.8-fold (0.25 log units) above the measured one; low and high end bracket the measured number.
By their numbers in this assay, from the lowest: compounds 4, 2 and 1 (each within the scatter of the next); then compound 3.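

In this assay the phenyl on this nitrogen responds to substitution: 5-chloro-2-methylphenyl in its place gives a 4.3-fold lower number from compound 3 to compound 4 (0.63 log units; beyond the scatter) and this is the only step shown that keeps the aromatic ring and changes what it carries. The step of a 1.9-fold lower number from compound 1 to compound 4 (0.29 log units; within the scatter) shows that the gap between 4-methylcyclohexyl and phenyl does not hold for every aromatic ring at this position. Nothing available explains the gain in potency.

The compounds shown leave open whether the chlorine, the methyl or both together account for the step, and whether a methoxy or an amine on the phenyl would do the same.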